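Trifluoromethyl in Place of Bromo on the Pendant Ring

A few compounds are considered here, and "the series" means these few. Any claim that something is new, unique, unknown or untested is made for them only; others in the source may bear on it.

The measured compounds, each with its number in an assay on isolated protein for displacement of a labelled ligand from acyl-CoA:cholesterol acyltransferase (Oryctolagus cuniculus); a higher number here means a weaker inhibitor, a lower number a stronger inhibitor:
Compound 1, `CC(C)c1cccc(C(C)C)c1NC(=O)Nc1nc2ccccc2n1-c1ccccc1Cl`, gives 18 nM.
Compound 2, `CC(C)c1cccc(C(C)C)c1NC(=O)Nc1nc2ccccc2n1-c1cccc(Cl)c1`, gives 20 nM.
Compound 3, `CC(C)c1cccc(C(C)C)c1NC(=O)Nc1nc2ccccc2n1-c1ccccc1Br`, gives 22 nM.

All three share the same core and differ only in the halogen-bearing ring on the aromatic nitrogen. Compound 3 sits within the scatter of both neighbours: a 1.2-fold higher number from compound 1 to compound 3 (0.09 log units; within the scatter), and a 1.1-fold higher number from compound 2 to compound 3 (0.04 log units; within the scatter). Moving the chlorine around the ring is equally quiet, as a 1.1-fold higher number from compound 1 to compound 2 (0.05 log units; within the scatter) shows.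

Compound 4, `CC(C)c1cccc(C(C)C)c1NC(=O)Nc1nc2ccccc2n1-c1ccccc1C(F)(F)F`, has not yet been measured. It differs from compound 3 in one place: trifluoromethyl in place of bromo on an aromatic carbon. The step that bears most directly on this change is the halogen swap at the same position, a 1.2-fold higher number from compound 1 to compound 3 (0.09 log units; within the scatter), which stayed within the scatter; the two steps on ring position, a 1.1-fold higher number from compound 1 to compound 2 (0.05 log units; within the scatter) and a 1.1-fold higher number from compound 2 to compound 3 (0.04 log units; within the scatter), were likewise flat. Going by the values given here, no measured step introduces a group larger than a halogen here, so the expectation rests on these three small moves only.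

On that basis compound 4 is expected to show no step beyond the scatter, a 1.1-fold higher number from compound 3 to compound 4 (0.04 log units; within the scatter), with an estimated value of 24 nM and a likely range from 10 nM to 60 nM.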

Compound 4, half-maximal inhibitory concentration: 72 nM
Compound 4: middle estimate off by 3.0-fold (0.48 log units), on the low side; the whole stated range lies below it.
By their numbers in this assay, from the lowest: compounds 1, 2 and 3 (each within the scatter of the next); then compound 4.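

In this assay, this position on the pendant ring proves not to be indifferent to what it carries: the halogen moves had left the number flat, whereas trifluoromethyl in place of bromo gives a clear weakening (a 3.3-fold higher number from compound 3 to compound 4 (0.51 log units; beyond the scatter)). The same weakening appears against the other two compounds, both for trifluoromethyl in place of chloro (a 4.0-fold higher number from compound 1 to compound 4 (0.60 log units; beyond the scatter)) and for 2-(trifluoromethyl)phenyl in place of 3-chlorophenyl (a 3.6-fold higher number from compound 2 to compound 4 (0.56 log units; beyond the scatter)), so compound 4 stands apart from three compounds that lie within the scatter of one another. Nothing given here accounts for this step, as no measurement of any property of these groups bears on it.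

The compounds shown leave open whether a methyl, a methoxy or a nitrile on this same aromatic carbon would stay with the halogens or go with trifluoromethyl. They also leave open whether a 3-(trifluoromethyl)phenyl group would cost as much as the 2-(trifluoromethyl)phenyl group does, given that the two chlorophenyl compounds could not be told apart.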